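A few compounds are considered here, and "the series" means these few. Any claim that something is new, unique, unknown or untested is made for them only; others in the source may bear on it.

In a functional assay on HCT-116 cells (Homo sapiens) for inhibition, read by MTT assay, with a stated time of 48 h (a lower number here means a stronger inhibitor, a higher number a weaker inhibitor), compound 1 `COc1ccc(-n2c(SCc3ccccc3)nnc2-c2cc(OC)c(OC)c(OC)c2)cc1` gives 42400 nM and compound 3 `COc1cc(-c2nnc(SCc3ccccc3)n2-c2ccc(N(C)C)cc2)cc(OC)c1OC` gives 54000 nM, so these two values lie within the scatter of each other. Compound 2 `COc1ccc(-n2c(SCC(=O)C3CC3)nnc2-c2cc(OC)c(OC)c(OC)c2)cc1` reads > 60000 nM, which is a limit of the assay and not a number. Compound 3 therefore sits level with compound 1, and no measured number separates them.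

Compound 4 `COc1cc(-c2nnc(SCC(=O)c3ccc4ccccc4c3)n2-c2ccc(N(C)C)cc2)cc(OC)c1OC` departs from compound 3 at a single place: (naphthalen-2-yl)carbonyl in place of phenyl on a saturated chain carbon bound to a sulfur.

For the measured compounds named here, two measured steps bear on this change. The closer one alters the same chain carbon: an at least 1.4-fold higher number from compound 1 to compound 2 (0.15 log units; that floor lies within the scatter), with cyclopropylcarbonyl in place of phenyl. The other, a 1.3-fold higher number from compound 1 to compound 3 (0.11 log units; within the scatter), has dimethylamino in place of methoxy on an aromatic carbon, and it links the two compounds that carry phenyl on the chain. Going by the values given here, neither step gives a firm size for the swap to (naphthalen-2-yl)carbonyl, and no measured compound carries that group.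

Compound 3 already reads 54000 nM, so little room is expected for a higher reading in this assay, and any real move is more likely toward a lower number. The expected step is modest and loosely held: a 2.7-fold lower number from compound 3 to compound 4 (0.43 log units; beyond the scatter). Compound 4 is estimated at 20000 nM, with an expected range of 3000 nM to 60000 nM.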

Compound 4, half-maximal inhibitory concentration: 54500 nM
Compound 4: the middle estimate sits 2.7-fold (0.44 log units) below what was measured, and the stated range covers the measured number.
By their numbers in this assay, from the lowest: compounds 1, 3 and 4 (each within the scatter of the next). At a limit, above all of these: compound 2.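

In this assay, the swap to (naphthalen-2-yl)carbonyl on a saturated chain carbon bound to a sulfur reads a 1.0-fold higher number from compound 3 to compound 4 (0.00 log units; within the scatter), so the two readings cannot be told apart even though the entering group brings a carbonyl and a second six-membered aromatic ring. For the compounds shown here, compound 2 carries a limit and not a number, so the earlier step at this place gave only a floor, whereas the pair of compound 3 and compound 4 is the first at this place with a number at both ends. With compound 4 added, none of the numbers shown is low, and readings this high leave little to separate changes at this place: the limit of > 60000 nM in this assay, at which 1 of the 4 values shown sits.

Going by these compounds, the carbonyl and the second ring enter together here, so phenylcarbonyl on the same chain carbon would be needed to tell their contributions apart, and the reading of (naphthalen-2-yl)carbonyl with methoxy in place of dimethylamino also remains open. On these data alone, whether an amine such as morpholine or a carboxylic acid at this place could give a clearly lower number in this assay is also open.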